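Cytotoxicity in Raji cells across a shared quinolone ester core

A few compounds are considered here, and "the series" means these few. Any claim that something is new, unique, unknown or untested is made for them only; others in the source may bear on it.

Measured so far:
compound 1, `CCOC(=O)c1c(-c2cccc(-c3ccccc3)c2)[nH]c2cc(OC)ccc2c1=O`, > 21500 nM
compound 2, `CCOC(=O)c1c(-c2cccc(OC)c2)[nH]c2cc(OC)ccc2c1=O`, > 21500 nM
compound 3, `CCOC(=O)c1c(-c2cccc(-c3ccccc3)c2)[nH]c2cc(Cl)c(Cl)cc2c1=O`, > 21500 nM

In an ADME assay on Raji cells (Homo sapiens) for cytotoxicity, read by luminescence, with a stated time of 72 h (a higher number here means that more compound is needed for the effect, a lower number that less compound is needed), compound 1 reaches only a limit, > 21500 nM. Compound 2 likewise gives only a limit, > 21500 nM. Compound 3 also sits at a limit, > 21500 nM. The change from compound 1 to compound 2 is methoxy in place of phenyl on an aromatic carbon; its step that the two limits leave unreadable from compound 1 to compound 2 cannot be read because of the limit of > 21500 nM in this assay, at which 3 of the 3 values shown sit. How the core of compound 3 differs from that of compound 1 is not broken down here.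

Compound 4, `CCOC(=O)c1c(-c2cccc(OC)c2)[nH]c2cc(Cl)c(Cl)cc2c1=O`, has not yet been measured. It differs from compound 3 by methoxy in place of phenyl on an aromatic carbon, the same change as that from compound 1 to compound 2. Compound 4 is expected to show a step that the limit leaves unreadable from compound 3 to compound 4 in this assay, an expectation resting on compound 3 sitting at > 21500 nM and on (the limit of > 21500 nM in this assay, at which 3 of the 3 values shown sit). The estimate for compound 4 is 30000 nM, between 15000 nM and 100000 nM.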

Compound 4, half-maximal effective concentration: > 21500 nM
Compound 4: only a limit was reported; the forecaster's own chance of this, stated with the estimate: 85%; the middle value lies beyond the limit too.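

Within the data shown here, compound 3 and compound 4 both give only a limit, so no step between them can be read: the limit of > 21500 nM in this assay, at which 4 of the 4 values shown sit. The compounds shown leave open whether methoxy in place of phenyl, or any difference in the core, alters cytotoxicity at all.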